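The source may hold more compounds than are shown below. What is called first, only, known or untested is meant among the compounds shown, and "the series" means these compounds.

Measured so far in a functional assay on A549 cells (Homo sapiens) for inhibition, read by MTT assay, with a stated time of 48 h; a lower number here means a stronger inhibitor, a higher number a weaker inhibitor:
- Compound 1 `COc1cccc(NC(=O)/C=C/c2coc3cc(OC)ccc3c2=O)c1`: 12800 nM
- Compound 2 `COc1ccc2c(=O)c(/C=C/C(=O)NCc3ccc(C)cc3)coc2c1`: > 100000 nM (a limit of the assay, not a number)
- Compound 3 `COc1ccc2c(=O)c(/C=C/C(=O)Nc3ccccc3C)coc2c1`: 23400 nM

Compound 3 gives 23400 nM, and the only other true number shown lies close to it: a 1.8-fold higher number from compound 1 to compound 3 (0.26 log units; within the scatter). These two compounds therefore cannot be told apart in this assay. Compound 2 gives > 100000 nM, which is a limit.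

The next compound is compound 4 `COc1ccc2c(=O)c(/C=C/C(=O)NCc3ccc(F)cc3F)coc2c1`, which keeps the shared core but carries 2,4-difluorobenzyl in place of 2-methylphenyl on the amide-type nitrogen: 2,4-difluorobenzyl in place of 2-methylphenyl on an amide-type nitrogen.

For the measured compounds named here, the closest guide is compound 2, the only measured compound with a benzyl-type group on that nitrogen. Going from that group to 2-methylphenyl gave an at least 4.2-fold lower number from compound 2 to compound 3 (0.63 log units; beyond the scatter), and the change from 3-methoxyphenyl to 4-methylbenzyl gave an at least 7.8-fold higher number from compound 1 to compound 2 (0.89 log units; beyond the scatter). Both steps point the same way, and both are bounds rather than exact sizes. The effect of the two fluorines has not been tested, so a somewhat smaller shift than these bounds is expected, though a limit remains quite possible.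

The expected change is a 2.6-fold higher number from compound 3 to compound 4 (0.41 log units; beyond the scatter).

Compound 4 is estimated at 60000 nM, with an expected range of 20000 nM to 180000 nM.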

Compound 4, half-maximal inhibitory concentration: 13300 nM
Compound 4: middle estimate off by 4.5-fold (0.65 log units), on the high side; measured number outside the range, below it.
By their numbers in this assay, from the lowest: compounds 1, 4 and 3 (each within the scatter of the next). At a limit, above all of these: compound 2.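

In this assay, a benzyl-type group on the amide-type nitrogen does not by itself push a compound out of the measurable range: swapping the ring substituents of that group, with 2,4-difluorophenyl in place of 4-methylphenyl, gives an at least 7.5-fold lower number from compound 2 to compound 4 (0.87 log units; beyond the scatter). As far as these compounds go, the true size of this step stays unknown, because compound 2 gives a limit and not a number: the limit of > 100000 nM in this assay, at which 1 of the 4 values shown sits. Compared with the two compounds that have a ring directly on that nitrogen, the new group brings no readable difference, with a 1.8-fold lower number from compound 3 to compound 4 (0.25 log units; within the scatter) and a 1.0-fold higher number from compound 1 to compound 4 (0.02 log units; within the scatter), so 2,4-difluorobenzyl, 2-methylphenyl and 3-methoxyphenyl cannot be told apart here.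

The compounds shown leave open whether the gain over compound 2 comes from one fluorine, from both, or simply from losing the methyl group, which a plain benzyl or a 4-fluorobenzyl group on the same nitrogen would help to separate. Also open, from the compounds shown here alone, is how a group of a different kind there, such as a short chain ending in an amine or a carboxylic acid, would read in this assay.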